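The source may hold more compounds than are shown below. What is called first, only, known or untested is meant among the compounds shown, and "the series" means these compounds.

Working notes on the series. Within the data shown here, compound 1 `Nc1nccc(-c2cc(OC3CCOC3)c3c(N)n[nH]c3c2)n1` stands at the top of the two measured members: in a physicochemical assay for solubility, read by LC-MS, in phosphate buffer, measured as kinetic solubility, with a stated time of 24 h, at 25 degrees C, at pH 7.4 (a lower number here means a less soluble compound, a higher number a more soluble compound), compound 1 gives 751000 nM, the highest of the two numbers. Compound 2 `Nc1nccc(-c2ccc3c(NCc4ccccc4)n[nH]c3c2)n1` carries a different substitution pattern on the shared core, and in this assay compound 2 gives 17000 nM, a gap from compound 1 that lies well beyond the scatter. Compound 3 `Nc1nccc(-c2cc(OC3CCOCC3)c3c(N)n[nH]c3c2)n1` is not yet measured. It differs from compound 1 in one place only, (oxan-4-yl in place of oxolan-3-yl on an oxygen on an aromatic ring). Among the measured compounds shown here, no measured pair shows this exchange, so the size of the step can be judged only from the change itself, which is a modest one. A small step is expected, a 1.5-fold lower number from compound 1 to compound 3 (0.18 log units; within the scatter), downward if anything and probably within the scatter. Compound 3 is accordingly expected to give about 500000 nM in this assay, within a range from 200000 nM to 1000000 nM.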

Compound 3, solubility: 770000 nM
Estimate against measurement, compound 3: 1.5-fold (0.19 log units) below; the measured number falls inside the stated range.
By their numbers in this assay, from the lowest: compound 2; then compounds 1 and 3 (each within the scatter of the next).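

The exchange of oxolan-3-yl for oxan-4-yl on an oxygen on an aromatic ring now has a measured size: in this assay it gives a 1.0-fold higher number from compound 1 to compound 3 (0.01 log units; within the scatter). At this position, therefore, the five-membered and the six-membered non-aromatic ring cannot be told apart in this read-out, at least on the core of compound 1. No measured evidence accompanies this step, and the data offer no account of why the two rings read alike.

As far as these compounds go, this exchange rests on a single pair, so whether it reads the same way on another core stays open. Also open, from the compounds shown here alone, is what a group of another kind on that oxygen would give in this assay, such as an amine or a carboxylic acid on a longer chain.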